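A few compounds are considered here, and "the series" means these few. Any claim that something is new, unique, unknown or untested is made for them only; others in the source may bear on it.

Compound 1 `O=C(/C=C/C(=O)N1C/C(=C\c2ccccc2)C(=O)/C(=C/c2ccccc2)C1)Nc1ccc([N+](=O)[O-])cc1` is the weakest of the three measured compounds in a functional assay on CCRF-CEM cells (Homo sapiens) for cytotoxicity; a lower number here means a stronger inhibitor, a higher number a weaker inhibitor: compound 1 gives 40000 nM. The two compounds that carry nitro groups on both benzylidene rings of the shared core sit far lower; in this assay compound 2 `O=C(/C=C/C(=O)N1C/C(=C\c2ccc([N+](=O)[O-])cc2)C(=O)/C(=C/c2ccc([N+](=O)[O-])cc2)C1)Nc1ccc([N+](=O)[O-])cc1` gives 410 nM and compound 3 `O=C(/C=C/C(=O)N1C/C(=C\c2ccc([N+](=O)[O-])cc2)C(=O)/C(=C/c2ccc([N+](=O)[O-])cc2)C1)Nc1ccc(Cl)cc1` gives 810 nM. No single-point step links compound 1 to either of them, so their values are only shown side by side.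

Compound 4 `COc1ccc(NC(=O)/C=C/C(=O)N2C/C(=C\c3ccccc3)C(=O)/C(=C/c3ccccc3)C2)cc1` differs from compound 1 by methoxy in place of nitro on an aromatic carbon of a six-membered aromatic ring of carbon only, para to a large group. Among the compounds with values here, the one measured step at this same position, a 2.0-fold higher number from compound 2 to compound 3 (0.30 log units; within the scatter), swapped the nitro for chloro and stayed within the scatter. A second swap of the same nitro is therefore expected to move the number little: a 1.3-fold higher number from compound 1 to compound 4 (0.10 log units; within the scatter) is the estimated step. Compound 4 is expected to give about 50000 nM in this assay, within a range from 18000 nM to 140000 nM.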

Compound 4, half-maximal inhibitory concentration: 510 nM
The estimate for compound 4 lay 98-fold (1.99 log units) above the measured number; measured number outside the range, below it.
By their numbers in this assay, from the lowest: compounds 2, 4 and 3 (each within the scatter of the next); then compound 1.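

This position is not as insensitive as the earlier step suggested: replacing 4-nitrophenyl with 4-methoxyphenyl gives a 78-fold lower number from compound 1 to compound 4 (1.89 log units; beyond the scatter) in this assay, whereas the earlier swap gave a 2.0-fold higher number from compound 2 to compound 3 (0.30 log units; within the scatter). The two swaps differ both in the group that enters and in the benzylidene rings of the core, which lack nitro groups in compound 1 and carry them in compound 2, so the effect of changing this nitro depends on at least one of those two differences. Nothing available here explains the size of the new step.

The compounds shown do not separate those two differences, as they include neither methoxy on the nitro-bearing core nor chloro on the core of compound 1. Also open, from the compounds shown here alone, is how an amine or a carboxylic acid at this same place on the ring would compare.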